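The compounds below may be only part of what the source reports. "The series", "measured", "known", "first", "only" and "open" are said of these compounds alone.

Measured so far:
compound 1, `Cn1cnc2c(Nc3ccccc3)ncnc21`: 0%
compound 2, `Cn1cnc2c(Nc3ccc(F)cc3)ncnc21`: 0%
compound 3, `Cn1cnc2c(Sc3ccccc3)ncnc21`: 0%

All three were run in an assay on isolated protein for inhibition of RAC-alpha serine/threonine-protein kinase (Homo sapiens), tested at 30 uM; a higher number here means more inhibition at the concentration tested (going by the name of the read-out), a lower number less inhibition. Compound 1 gives 0% in this assay, compound 2 gives 0%, and compound 3 gives 0%; the three values stand at the same digits.

Compound 2 is obtained from compound 1 by one change, (fluoro in place of hydrogen on an aromatic carbon). The step this change made in this assay is no change at the digits printed from compound 1 to compound 2 (within the scatter).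

Compound 3 carries a different core from compound 1; the difference between the two cores is not broken down here. For the measured compounds named here, what the values show is only that compound 3 and compound 1 read the same at the digits printed, as do compound 3 and compound 2.

Compound 4, `Cn1cnc2c(Sc3ccc(F)cc3)ncnc21`, has not yet been measured in this assay. It is obtained from compound 3 by fluoro in place of hydrogen on an aromatic carbon, the same change that leads from compound 1 to compound 2, at the same place on the ring.

Since that change gave no change at the digits printed from compound 1 to compound 2 (within the scatter), and since compound 3 sits where compound 1 sits, with compound 3 giving 0% in this assay, compound 4 is expected to show the step of no change at the digits printed from compound 3 to compound 4 (within the scatter). Compound 4 is therefore estimated to give about 0% in this assay, with the expected range running from -8% to 10%.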

Compound 4, a percentage reported as inhibition, at one concentration (the size of the read-out at that concentration, not a potency): 0%
For compound 4 middle estimate and measured number coincide at the digits printed, and the stated range covers the measured number.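

In this assay, fluoro in place of hydrogen on an aromatic carbon gives no change at the digits printed from compound 3 to compound 4 (within the scatter), and this step agrees with the one seen on the other core: the same change on two cores in this assay, no change at the digits printed (within the scatter) from compound 1 to compound 2 and no change at the digits printed (within the scatter) from compound 3 to compound 4, 0 percentage points apart, within the scatter of two such steps Within these two cores, then, the change carries over with no difference that the readings can show. This is weak evidence of transfer, however: compound 1, compound 2 and compound 3 read the same as compound 4 at 0%, so both steps start and end with no measurable inhibition, and they cannot show whether the change would carry over on a compound that registers inhibition in this assay.

The compounds shown leave open whether any group on this ring other than fluoro, such as an amine, a carboxylic acid or a longer chain, would move the reading away from this shared level. They also leave open whether fluoro at another place on the ring, or the same change on a core that does show inhibition, would produce a step that can be read.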